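Cytotoxicity notes: from compound 2 to compound 4

The source may report more compounds than this note shows. Statements on the series, on what has been measured and on what is new or still open speak of the compounds shown alone.

Compound 2 `O=C1N(Cc2ccccc2Cl)c2cccn2S(=O)(=O)N1Cc1ccccc1` was read in an ADME assay on MT4 cells (Homo sapiens) for cytotoxicity, read by MTT assay, with a stated time of 5 days (on this read-out higher numbers stand for lower toxicity in this test and lower numbers for higher toxicity in this test), and gives only a limit, > 291000 nM, not a number. Compound 1 `C=CCN1C(=O)N(Cc2ccccc2)S(=O)(=O)n2cccc21` likewise gives only a limit in this assay, > 802000 nM. Compound 3 `O=C1N(Cc2ccccc2Cl)c2cccn2S(=O)(=O)N1Cc1cccc(Br)c1` also reaches only a limit in this assay, > 260000 nM. With all three values at limits, compound 2 cannot be placed relative to the others: a step that the two limits leave unreadable from compound 1 to compound 2 and a step that the two limits leave unreadable from compound 2 to compound 3 are both unreadable, the values sitting at the limit of > 291000 nM in this assay, at which 1 of the 3 values shown sits, the limit of > 802000 nM in this assay, at which 1 of the 3 values shown sits, and (the limit of > 260000 nM in this assay, at which 1 of the 3 values shown sits). Compound 4 `O=C1N(C/C=C/c2ccccc2)c2cccn2S(=O)(=O)N1Cc1ccccc1` differs from compound 2 by 2-phenylethenyl in place of 2-chlorophenyl on a saturated chain carbon bound to an amide-type nitrogen in a ring. Neither measured step gives a readable size or direction for this change in this assay. Compound 4 is therefore expected to show a step that the limit leaves unreadable from compound 2 to compound 4. Compound 4 is estimated at 300000 nM, between 100000 nM and 1000000 nM, most likely reported again as a limit.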

Compound 4, half-maximal cytotoxic concentration: > 318000 nM
Compound 4: only a limit was reported (the forecaster's own chance of this, stated with the estimate: 80%); middle value at least 1.0-fold (0.02 log units) away from the limit.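

Among these compounds, compound 4 gives only a limit, as do compound 1 and compound 2, so no step from either to compound 4 can be read. On these data alone, whether 2-phenylethenyl changes cytotoxicity stays open.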